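The source may hold more compounds than are shown below. What is called first, only, known or untested is meant among the compounds shown, and "the series" means these compounds.

In an assay on cells for antagonist activity at transient receptor potential cation channel subfamily V member 1 (Homo sapiens), read by FLIPR and calcium flux, with a stated time of 6 min (a higher number here means a weaker inhibitor, a lower number a stronger inhibitor), compound 3 `CCCCOc1cc(C(C)(C)C)ccc1CNC(=O)C(C)c1ccc(NS(C)(=O)=O)c(F)c1` gives 1.4 nM, the lowest of the three numbers recorded; compound 1 `CC(C(=O)NCc1ccc(C(C)(C)C)nc1OC1CCCCC1)c1ccc(NS(C)(=O)=O)c(F)c1` gives 2.5 nM, a gap within the scatter, while compound 2 `CC(C(=O)NCc1ccc(C(C)(C)C)nc1OCc1ccccc1)c1ccc(NS(C)(=O)=O)c(F)c1` gives 4.4 nM, a gap beyond it. Compound 4 `CCCCCc1cc(C(C)(C)C)ccc1CNC(=O)C(C)c1ccc(NS(C)(=O)=O)c(F)c1` differs from compound 3 in one place: pentyl in place of butoxy on an aromatic carbon. For the measured compounds named here, the only measured step, a 1.8-fold higher number from compound 1 to compound 2 (0.25 log units; within the scatter), swaps one group for another on an oxygen on an aromatic ring and stays within the scatter, so it bears only loosely on a change that removes the oxygen itself. Going by the values given here, no measured pair speaks directly to this exchange. Compound 4 is therefore expected to sit near compound 3, with a step of a 1.6-fold higher number from compound 3 to compound 4 (0.20 log units; within the scatter) and an estimated value of 2.2 nM, ranging from 0.7 nM to 7 nM.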

Compound 4, inhibition constant: 2.8 nM
For compound 4 the middle estimate is 1.3-fold (0.10 log units) below the measured one, and the stated range covers the measured number.
By their numbers in this assay, from the lowest: compounds 3, 1, 4 and 2 (each within the scatter of the next, the first and the last beyond it).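

In this assay, the exchange of butoxy for pentyl gives a 2.0-fold higher number from compound 3 to compound 4 (0.30 log units; within the scatter). Earlier compounds only varied the group on the oxygen, whereas this step shows that the oxygen, and with it the hydrogen-bond acceptor counted in butoxy, can be replaced by carbon on this aromatic carbon without a step beyond the scatter. Nothing available explains this result. As far as these compounds go, it remains open whether an amine in place of the oxygen, or a longer chain, would also stay within the scatter at this position. From the compounds shown here alone, whether pentyl would behave alike on the core of compound 1 is equally open.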